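From 2,5-dimethoxyphenyl to 2,4-dimethoxyphenyl: an expected step

The compounds below may be only part of what the source reports. "The series", "measured", "known", "first", "only" and "open" are said of these compounds alone.

In a functional assay on MCF7 cells (Homo sapiens) for cytotoxicity, read by MTT assay, with a stated time of 72 h (a higher number here means a weaker inhibitor, a lower number a stronger inhibitor), three compounds have been measured so far. Compound 1 `O=C(/C=C/c1ccc([N+](=O)[O-])cc1)Nc1cc2c(Nc3ccc(F)c(Cl)c3)ncnc2cc1O[C@H]1CCOC1` gives 26700 nM, compound 2 `COc1ccc(OC)c(/C=C/C(=O)Nc2cc3c(Nc4ccc(F)c(Cl)c4)ncnc3cc2OC)c1` gives 34300 nM and compound 3 `COc1cc(/C=C/C(=O)Nc2cc3c(Nc4ccc(F)c(Cl)c4)ncnc3cc2O[C@H]2CCOC2)cc(OC)c1OC` gives 28400 nM. Compound 2 lies within the scatter of both the others, so these three numbers cannot be put in any order.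

Compound 4 `COc1ccc(/C=C/C(=O)Nc2cc3c(Nc4ccc(F)c(Cl)c4)ncnc3cc2OC)c(OC)c1` has the same atoms as compound 2, joined differently: 2,4-dimethoxyphenyl in place of 2,5-dimethoxyphenyl on a double-bonded chain carbon bound to a double-bonded chain carbon. Here 2,4-dimethoxyphenyl takes the place of 2,5-dimethoxyphenyl on a double-bonded chain carbon bound to a double-bonded chain carbon.

For the measured compounds named here, no measured pair yet isolates this kind of exchange between two dimethoxyphenyl groups. Going by the values given here, the nearest evidence is the one measured step, a 1.1-fold higher number from compound 1 to compound 3 (0.03 log units; within the scatter), where 3,4,5-trimethoxyphenyl replaces 4-nitrophenyl at the same place. Even that exchange of two differently substituted groups stays within the scatter. One step is thin evidence, but it gives no reason to expect a real shift in this assay from compound 2 to compound 4, and no direction is favoured. The estimated step is a 1.1-fold lower number from compound 2 to compound 4 (0.04 log units; within the scatter), which is expected to remain within the scatter. For compound 4 the expected value is 31000 nM, with an estimated range of 15000 nM to 60000 nM.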

Compound 4, half-maximal inhibitory concentration: 36600 nM
Estimate against measurement, compound 4: 1.2-fold (0.07 log units) below, and the stated range covers the measured number.
By their numbers in this assay, from the lowest: compounds 1, 3, 2 and 4 (each within the scatter of the next).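

In this assay, for the compounds shown here, the exchange of 2,5-dimethoxyphenyl for 2,4-dimethoxyphenyl on a double-bonded chain carbon bound to a double-bonded chain carbon gives a 1.1-fold higher number from compound 2 to compound 4 (0.03 log units; within the scatter) and is the first pair to isolate a change between two dimethoxyphenyl groups. Alongside a 1.1-fold higher number from compound 1 to compound 3 (0.03 log units; within the scatter) and its exchange of two differently substituted groups, there are now two readable steps at this place, and neither leaves the scatter, so neither a rearrangement of the same atoms nor the broader exchange shows this place responding in this assay. No separate evidence bears on this result.

Every group shown at this place is a phenyl ring carrying methoxy or nitro groups, so it remains open whether a phenyl ring carrying an amine or a carboxylic acid, or a longer chain between the carbonyl and the ring, would shift the number in this assay beyond the scatter. The dimethoxyphenyl exchange is also read only on the core of compound 2, which leaves open whether the same step would stay within the scatter on the core of compound 3.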